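The source may hold more compounds than are shown below. What is called first, only, known or untested is meant among the compounds shown, and "the series" means these compounds.

- Compound 1 `O=C(Nc1ccc([N+](=O)[O-])cc1Cl)c1cccc2cc[nH]c12`: < 1 ug/mL
- Compound 2 `O=C(Nc1ccncc1Cl)c1cc(Cl)ccc1O`: 6.5 ug/mL

Within the data shown here, both compounds have been tested in a physicochemical assay for solubility; a lower number here means a less soluble compound, a higher number a more soluble compound. In this assay, compound 1 gives < 1 ug/mL. That figure is a limit of the assay and not a number, so the true standing of compound 1 is known only as this limit. Compound 2 gives 6.5 ug/mL, but its structure differs from compound 1 in more than one place, so it offers no direct guide here.

The next compound, compound 3 `N#Cc1ccc(NC(=O)c2cccc3cc[nH]c23)c(Cl)c1`, keeps the core of compound 1 and makes one change: cyano in place of nitro on an aromatic carbon, meta to a chloro group and para to a large group (cyano in place of nitro on an aromatic carbon). Among the measured compounds shown here, no measured pair of compounds shows what this swap does, so any forecast is loose. A small rise in this assay is expected, perhaps none beyond the usual scatter, and compound 3 may well also end up reported as a limit. The expected change is an at least 1.5-fold higher number from compound 1 to compound 3 (0.17 log units; that floor lies within the scatter). For compound 3 the estimate is 1.5 ug/mL, with an expected range from 0.5 ug/mL to 6 ug/mL.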

Compound 3, solubility: < 1 ug/mL
Compound 3: a limit, no number (the forecaster's own chance of this, stated with the estimate: 45%); middle value at least 1.5-fold (0.17 log units) away from the limit.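

In this assay compound 1 and compound 3 each give a limit and not a number, so no step can be read for cyano in place of nitro, because both results stop at the same limit: the limit of < 1 ug/mL in this assay, at which 2 of the 3 values shown sit.

The compounds shown leave open how far the true values of compound 1 and compound 3 lie from that limit, and whether this swap shifts the result in this assay at all.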